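A few compounds are considered here, and "the series" means these few. Any claim that something is new, unique, unknown or untested is made for them only; others in the source may bear on it.

Measured compounds:
Compound 1 `Cc1ccc2c(c1)C1(C(=O)N2C)C(C#N)=C(N)Oc2cc3oc(-c4ccccc4)cc(=O)c3c(O)c21` gives 10200 nM in a functional assay on NCI-H1299 cells (Homo sapiens) for antiproliferative activity, read by MTT assay, with a stated time of 48 h; a lower number here means a stronger inhibitor, a higher number a weaker inhibitor.
Compound 2 `CN1C(=O)C2(C(C#N)=C(N)Oc3cc4oc(-c5ccccc5)cc(=O)c4c(O)c32)c2cc(Cl)ccc21` gives 11200 nM in this assay.

Compound 1 holds the lower of the two numbers, yet the step of a 1.1-fold higher number from compound 1 to compound 2 (0.04 log units; within the scatter) is small, so the two values cannot be told apart. Compound 3 `COc1ccc(-c2cc(=O)c3c(O)c4c(cc3o2)OC(N)=C(C#N)C42C(=O)N(C)c3ccc(C)cc32)c(OC)c1` has not been measured. It differs from compound 1 in one place: 2,4-dimethoxyphenyl in place of phenyl on an aromatic carbon. Going by the values given here, the only measured step swaps a chloro for a methyl on a different aromatic ring of the shared core, and it left the number essentially unchanged; it says nothing direct about replacing phenyl with 2,4-dimethoxyphenyl, so no measured step bears on this change. With no guide, the step from compound 1 to compound 3 is expected to be modest in either direction, a 1.1-fold lower number from compound 1 to compound 3 (0.05 log units; within the scatter). Compound 3 is therefore estimated to give 9000 nM in this assay, with a range from 3000 nM to 30000 nM.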

Compound 3, half-maximal inhibitory concentration: > 50000 nM
Compound 3 ended at the assay's limit (the forecaster's own chance of this, stated with the estimate: 10%); middle value at least 5.5-fold (0.74 log units) from the limit.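

In this assay compound 3 gives > 50000 nM, which is a limit of the assay and not a number. Going by these compounds alone, this is the first sign that the position holding the phenyl group responds to a change: 2,4-dimethoxyphenyl in place of phenyl gives an at least 4.9-fold higher number from compound 1 to compound 3 (0.69 log units; beyond the scatter), whereas chloro in place of methyl on a different aromatic ring gave a 1.1-fold higher number from compound 1 to compound 2 (0.04 log units; within the scatter). The compound is weaker with the new group, but the size of the loss can be stated only as a minimum: the limit of > 50000 nM in this assay, at which 1 of the 3 values shown sits.

The two methoxy groups enter together, so the compounds shown leave open whether either one alone would give the same result. They also do not show how a phenyl ring carrying an amine or a carboxylic acid would behave at this position.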